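The source may hold more compounds than are shown below. What is called first, only, known or untested is meant among the compounds shown, and "the series" means these compounds.

Of the compounds shown here, three that share one core have been tested in a functional assay on CCRF-CEM cells for antagonist activity at C-X-C chemokine receptor type 4 (Homo sapiens), read by calcium flux, with stated times of 25 min and 90 s; on this read-out lower numbers stand for stronger inhibition and higher numbers for weaker inhibition. Compound 1 `CN(C)[C@H]1CCN(c2cccc3c2C[C@H](CN(C)[C@H]2CCCc4cccnc42)NC3)C1` gives 10.9 nM in this assay, and compound 2 `CN(C)[C@@H]1CCN(c2cccc3c2C[C@H](CN(C)[C@H]2CCCc4cccnc42)NC3)C1` gives 10.4 nM; the step of a 1.0-fold lower number from compound 1 to compound 2 (0.02 log units; within the scatter) stays within the scatter, which is consistent with the fact that compounds 1 and 2 differ only in the configuration as drawn. Compound 3 `CN(C)C1CCN(c2cccc3c2C[C@H](CN(C)[C@H]2CCCc4cccnc42)NC3)CC1` gives 35.9 nM, the highest number of the three: the step of a 3.3-fold higher number from compound 1 to compound 3 (0.52 log units; beyond the scatter) and the step of a 3.5-fold higher number from compound 2 to compound 3 (0.54 log units; beyond the scatter) both show weaker inhibition when 4-(dimethylamino)piperidin-1-yl stands in place of 3-(dimethylamino)pyrrolidin-1-yl on the aromatic carbon.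

Compound 4 `CN(C[C@H]1Cc2c(cccc2N[C@H]2CC[C@H](N)CC2)CN1)[C@H]1CCCc2cccnc21` differs from compound 3 in that ((4-aminocyclohexyl)amino in place of 4-(dimethylamino)piperidin-1-yl on an aromatic carbon). Among the measured compounds shown here, none of the measured steps covers this kind of exchange; they compare two ring sizes of an amine-bearing ring, or a change of configuration alone, so they bear on the new step only loosely, suggesting that amine-bearing groups at this position are tolerated with modest differences. The step of a 1.4-fold lower number from compound 3 to compound 4 (0.16 log units; within the scatter) is therefore expected to be small, in either direction. Compound 4 is estimated at 25 nM, with a range from 6 nM to 100 nM.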

Compound 4, half-maximal inhibitory concentration: 755 nM
Compound 4: middle estimate off by 30-fold (1.48 log units), on the low side; measured number outside the range, above it.
By their numbers in this assay, from the lowest: compounds 2 and 1 (each within the scatter of the next); then compound 3; then compound 4.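

In this assay, this position does not accept every amine-bearing ring alike: (4-aminocyclohexyl)amino in place of 4-(dimethylamino)piperidin-1-yl gives a 21-fold higher number from compound 3 to compound 4 (1.32 log units; beyond the scatter), and in place of 3-(dimethylamino)pyrrolidin-1-yl it gives a 73-fold higher number from compound 2 to compound 4 (1.86 log units; beyond the scatter) and a 69-fold higher number from compound 1 to compound 4 (1.84 log units; beyond the scatter). Among the compounds shown here, the earlier steps at this aromatic carbon were modest or within the scatter, so these are the first large ones seen here. The entering group differs from the leaving ones in several ways at once, with a ring of carbon only and with hydrogen-bond donors, and nothing measured here explains the loss.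

Still open, as far as these compounds go, is whether the loss follows the free primary amine or the amine nitrogen joining the ring to the aromatic carbon, a question that 4-aminopiperidin-1-yl would help to separate. From the compounds shown here alone, the effect of the opposite configuration on the cyclohexyl ring also remains open.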